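From Phenyl to 4-Chlorophenyl on Compound 2

The compounds below may be only part of what the source reports. "The series", "measured", "known", "first", "only" and "open" are said of these compounds alone.

Among the measured compounds shown here, only two compounds with this shared core have numbers so far in a functional assay on HCT-116 cells (Homo sapiens) for antiproliferative activity, read by MTT assay, with a stated time of 72 h (a lower number here means a stronger inhibitor, a higher number a weaker inhibitor), and they differ in one place. Compound 1 (`O=C(CCc1cccc2c1B(O)OC2)Nc1cccc(Br)c1`) carries a bromo group and gives 1400 nM as its result, while compound 2 (`O=C(CCc1cccc2c1B(O)OC2)Nc1cccc(-c2ccccc2)c1`) carries a phenyl group there and gives 890 nM as its result. For the measured compounds named here, compound 2 therefore stands level with compound 1, its only point of comparison. Going by the values given here, the one measured step, a 1.6-fold lower number from compound 1 to compound 2 (0.20 log units; within the scatter) is small, and it is the only evidence that bears on the next change.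

Compound 3 (`O=C(CCc1cccc2c1B(O)OC2)Nc1cccc(-c2ccc(Cl)cc2)c1`) turns the phenyl group of compound 2 into 4-chlorophenyl, with chloro in place of hydrogen on an aromatic carbon. Among the compounds with values here, no measured compound yet carries any group on that phenyl ring, so the data give no direction for this change. The size of the earlier step suggests a modest move, so the expected change in this assay is none beyond the scatter, an estimated 1.2-fold lower number from compound 2 to compound 3 (0.07 log units; within the scatter) and no more. Compound 3 is expected to give about 750 nM as its result. The estimated range for compound 3 runs from 280 nM to 2000 nM as its likely span.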

Compound 3, half-maximal inhibitory concentration: 380 nM
Estimate against measurement, compound 3: 2.0-fold (0.30 log units) above; measured number inside the range.
By their numbers in this assay, from the lowest: compound 3; then compounds 2 and 1 (each within the scatter of the next).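

In this assay, swapping bromo for phenyl had given no change beyond the scatter, so the outer ring looked like a place where little might happen. Among the compounds shown here, a single chloro on that ring, para to a large group, now gives a 2.3-fold lower number from compound 2 to compound 3 (0.37 log units; beyond the scatter), the first step in this small set that clears the scatter, so this position does respond to a change of just one heavy atom. Compound 3 also separates clearly from the bromo starting point, with a 3.7-fold lower number from compound 1 to compound 3 (0.57 log units; beyond the scatter), which makes it the most potent of the three compounds, although the gain remains modest and nothing available here accounts for it.

From the compounds shown here alone, with only hydrogen and chloro compared at this position, it remains open whether the effect is particular to chloro or would also appear with fluoro, methyl, methoxy, an amine or a carboxylic acid in the same place. Going by these compounds, it is equally open whether chloro at another carbon of that ring would lower the number as far, or whether a larger group at this position would lower it further.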